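Aryl-amine pyridines bearing a diazabicycle: nitro to chloro

The source may report more compounds than this note shows. Statements on the series, on what has been measured and on what is new or still open speak of the compounds shown alone.

Measured so far in an assay on cell membranes for displacement of a labelled ligand from Neuronal acetylcholine receptor; alpha4/beta2 (Rattus norvegicus); on this read-out higher numbers stand for weaker inhibition and lower numbers for stronger inhibition:
compound 1 `Oc1ccc(Nc2cncc(N3CC4CC(C3)N4)c2)cc1` gives 0.342 nM
compound 2 `O=[N+]([O-])c1ccc(Nc2ccc(N3CC4CC(C3)N4)cn2)cc1` gives 1.76 nM
compound 3 `FC(F)(F)c1ccc(Nc2cncc(N3CC4CC(C3)N4)c2)cc1` gives 0.373 nM

Compound 2 stands at the highest of the three numbers, beyond the scatter from both compound 3 and compound 1. For the measured compounds named here, the one step between measured compounds, a 1.1-fold higher number from compound 1 to compound 3 (0.04 log units; within the scatter), lies within the scatter and concerns a different core and different groups, so it gives no direct guidance. Compound 4 `Clc1ccc(Nc2ccc(N3CC4CC(C3)N4)cn2)cc1` keeps the core of compound 2; the change is chloro in place of nitro on an aromatic carbon. Going by the values given here, with no comparable step in hand, the expectation for compound 4 in this assay is a modest step, a 1.2-fold lower number from compound 2 to compound 4 (0.07 log units; within the scatter), with no firm direction. Compound 4 is estimated at 1.5 nM, in the range 0.5 nM to 4.5 nM.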

Compound 4, inhibition constant: 2.49 nM
Beside the measured number, compound 4's estimate is 1.7-fold (0.22 log units) below it; low and high end bracket the measured number.
By their numbers in this assay, from the lowest: compounds 1 and 3 (each within the scatter of the next); then compounds 2 and 4 (each within the scatter of the next).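

In this assay, chloro in place of nitro on the aromatic carbon para to a large group leaves the number within the scatter (a 1.4-fold higher number from compound 2 to compound 4 (0.15 log units; within the scatter)) on the core of compound 2. At this position, therefore, the nitro group's 3 heavy atoms and 2 hydrogen-bond acceptors can give way to a single chlorine without a step beyond the scatter. No evidence on the reason for this is at hand.

On these data alone, whether an amine or a carboxylic acid at this position would also stay within the scatter remains open. So does the reading of a methoxy group here.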